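The source may report more compounds than this note shows. Statements on the series, on what has been measured and on what is new or still open speak of the compounds shown alone.

Going by the values given here, compound 1 `Cc1nc(CN2CCN(c3cccc4[nH]c(-c5ccc(C(C)(C)C)cc5)nc34)CC2)c[nH]1` gives 7.5 nM in an assay on isolated protein for displacement of a labelled ligand from Gonadotropin-releasing hormone receptor (Homo sapiens) (a higher number here means a weaker inhibitor, a lower number a stronger inhibitor), the lower of the two numbers measured so far, while compound 2 `CCc1nc(C)c(CN2CCN(c3cccc4[nH]c(-c5ccc(C(C)(C)C)cc5)nc34)CC2)o1` gives 37 nM in this assay. Compound 3 `Cc1nc(C)c(CN2CCN(c3cccc4[nH]c(-c5ccc(C(C)(C)C)cc5)nc34)CC2)s1` carries 2,4-dimethyl-1,3-thiazol-5-yl in place of 2-methyl-1H-imidazol-4-yl on a saturated chain carbon bound to an amine nitrogen in a ring. Among the compounds with values here, the one measured step that bears on this change, a 4.9-fold higher number from compound 1 to compound 2 (0.69 log units; beyond the scatter), also replaced the 2-methyl-1H-imidazol-4-yl with another five-membered aromatic ring with 2 hetero atoms, at a modest cost. A step of similar size and the same direction, a 4.0-fold higher number from compound 1 to compound 3 (0.60 log units; beyond the scatter), is therefore expected here. Compound 3 is estimated at 30 nM, with a range from 9 nM to 100 nM.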

Compound 3, half-maximal inhibitory concentration: 27 nM
Compound 3: the middle estimate sits 1.1-fold (0.05 log units) above what was measured; the range from low to high includes it.
By their numbers in this assay, from the lowest: compound 1; then compounds 3 and 2 (each within the scatter of the next).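

The 2,4-dimethyl-1,3-thiazol-5-yl replacement also costs binding relative to 2-methyl-1H-imidazol-4-yl (a 3.6-fold higher number from compound 1 to compound 3 (0.56 log units; beyond the scatter)), so on a saturated chain carbon bound to an amine nitrogen in a ring, both replacement rings shown move the number the same way. The thiazole and oxazole groups cannot be told apart (a 1.4-fold lower number from compound 2 to compound 3 (0.14 log units; within the scatter)). Nothing measured here explains why compound 1 has the lowest number.

The compounds shown leave open how a pyridine or a 1,2,4-triazole would fare at this place. They also leave open whether the methyl on the imidazole matters.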